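The compounds below may be only part of what the source reports. "The series", "measured", "known", "first", "only" and "open" are said of these compounds alone.

In an ADME assay on L929 cells (Mus musculus) for cytotoxicity, read by resazurin assay, with a stated time of 72 h (on this read-out higher numbers stand for weaker inhibition and lower numbers for stronger inhibition), two compounds have been measured, and both results come back as limits rather than numbers. Compound 1, `OB1OCc2ccc(-n3cccc3Sc3ccccc3Cl)cc21`, gives in this assay a limit of > 10 ug/mL. Compound 2, `O=C(c1ccn(-c2ccc3c(c2)B(O)OC3)c1)c1ccccc1Cl`, gives in this assay a limit of > 10 ug/mL. So compound 2 stands at the same limit as the only other compound measured, and nothing distinguishes the two on these data; the evidence amounts to the limit of > 10 ug/mL in this assay, at which 2 of the 2 values shown sit.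

Compound 3, `O=C(c1ccn(-c2ccc3c(c2)B(O)OC3)c1)C1CCCCC1`, remains to be measured in this assay. It differs from compound 2 in one place: cyclohexyl in place of 2-chlorophenyl on a carbonyl carbon. Within the data shown here, with no measured step of any kind, and with both known values sitting at the limit, there is no basis for expecting movement in either direction, and the expected change is a step that the limit leaves unreadable from compound 2 to compound 3, that is, none beyond the scatter. The most likely outcome for compound 3 is again a result at the limit. For compound 3 the estimate in this assay is 15 ug/mL, expected to lie between 7 ug/mL and 50 ug/mL.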

Compound 3, half-maximal inhibitory concentration: > 10 ug/mL
Compound 3: no number, only a limit; the forecaster's own chance of this, stated with the estimate: 80%; the middle value does not contradict the limit.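

In this assay compound 3 gives > 10 ug/mL as a limit and not a number. Compound 2 is also reported only as a limit, and no step can be read between compound 2 and compound 3. The compounds shown leave open at what concentration any of them would inhibit the cells, and whether cyclohexyl in place of 2-chlorophenyl changes that, the data reaching only this far: the limit of > 10 ug/mL in this assay, at which 3 of the 3 values shown sit.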